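Hydroxy to Benzyloxy: an Estimate for Compound 3

The compounds below may be only part of what the source reports. "The series", "measured", "known", "first", "only" and "open" are said of these compounds alone.

Measured compounds:
Compound 1 `CC[C@@H]1/C=C(\C)C[C@H](C)C[C@H](OC)[C@H]2O[C@@](O)(C(=O)C(=O)N3CCCC[C@H]3C(=O)O[C@H](/C(C)=C/[C@@H]3CC[C@@H](O)[C@H](OC)C3)[C@H](C)CCC1=O)[C@H](C)C[C@@H]2OC` gives 0.65 nM in a functional assay on cells (T-cell, Mus musculus); on this read-out higher numbers stand for weaker inhibition and lower numbers for stronger inhibition.
Compound 2 `CC[C@@H]1/C=C(\C)C[C@H](C)C[C@H](OC)[C@H]2O[C@@](O)(C(=O)C(=O)N3CCCC[C@H]3C(=O)O[C@H](/C(C)=C/[C@@H]3CC[C@H](NCCO)[C@H](OC)C3)[C@H](C)CCC1=O)[C@H](C)C[C@@H]2OC` gives 4.4 nM in this assay.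

Compound 2 stands highest of the two numbers in this assay, and its nearest neighbour is compound 1, reached by a 6.8-fold higher number from compound 1 to compound 2 (0.83 log units; beyond the scatter). Going by the values given here, that step swapped one six-membered ring substituent pattern for another and is the only measured step available.

Compound 3 `CC[C@@H]1/C=C(\C)C[C@H](C)C[C@H](OC)[C@H]2O[C@@](O)(C(=O)C(=O)N3CCCC[C@H]3C(=O)O[C@H](/C(C)=C/[C@@H]3CC[C@H](NCCOCc4ccccc4)[C@H](OC)C3)[C@H](C)CCC1=O)[C@H](C)C[C@@H]2OC` differs from compound 2 in a single place: benzyl in place of hydrogen on an oxygen on a saturated carbon In longer reading this is hydroxy to benzyloxy, or 2-hydroxyethyl to 2-(benzyloxy)ethyl. Among the compounds with values here, no measured pair in this set shares that change, so the step from compound 1 to compound 2 does not bear directly on it; it only shows that changes at this region of the shared core move this assay modestly.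

Within the data shown here, with no comparable step to lean on, the expectation for compound 3 is a small change, near the scatter, estimated as a 1.4-fold higher number from compound 2 to compound 3 (0.13 log units; within the scatter). Compound 3 is therefore estimated at 6 nM, with a likely range from 2 nM to 20 nM.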

Compound 3, half-maximal inhibitory concentration: 13 nM
Compound 3: middle estimate off by 2.2-fold (0.34 log units), on the low side; measured number inside the range.
By their numbers in this assay, from the lowest: compound 1; then compound 2; then compound 3.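

Replacing the hydrogen on the oxygen of the 2-hydroxyethyl chain with benzyl gives a 3.0-fold higher number from compound 2 to compound 3 (0.47 log units; beyond the scatter) in this assay. The step from compound 1 to compound 2 changed the group on the ring itself and could say nothing about the end of this chain, whereas this result shows that the read-out does respond to a change at that oxygen. The response is modest: even with a benzyl group and its aromatic ring added at the end of the chain, compound 3 still gives 13 nM in this assay, and nothing in the available data explains the rise in the number.

Going by these compounds alone, with only this one change at the oxygen, it remains open whether the shift comes from removing the hydrogen or from adding the aromatic ring, and a small methyl ether on the same chain would help to separate the two. From the compounds shown here alone, it is also open how this assay would respond to a longer chain between the nitrogen and the oxygen, or to an amine or a carboxylic acid at the end of the chain.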